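The source may hold more compounds than are shown below. What is called first, only, known or untested is meant among the compounds shown, and "the series" means these compounds.

Compound 2 `CSc1ccc(COCC#CC(O)c2ccc(C(C)C)cc2)cc1` sits at the low end of the three numbers measured in a functional assay on COLO 205 cells (Homo sapiens) for inhibition, read by MTT assay, with a stated time of 48 h; on this read-out higher numbers stand for weaker inhibition of growth and lower numbers for stronger inhibition of growth: compound 2 gives 12000 nM. Among the measured compounds shown here, its closest neighbour is compound 1 `CSc1ccc(COCC#CC(O)c2ccc(F)cc2)cc1`, which in this assay gives 22000 nM; the one change between them, isopropyl in place of fluoro on an aromatic carbon, produced a 1.8-fold lower number from compound 1 to compound 2 (0.26 log units; within the scatter). The third compound, compound 3 `COc1cc(C(O)C#CCOCc2ccc(SC)cc2)cc(OC)c1OC`, gives 100000 nM in this assay, a number that stands well apart from compound 2, beyond the scatter.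

Compound 4 `CSc1ccc(COCC#CC(O)c2ccc(C#N)cc2)cc1` is the next compound, not yet measured. It differs from compound 2 in one place: cyano in place of isopropyl on an aromatic carbon, on an aromatic carbon of a six-membered aromatic ring of carbon only, para to a large group. For the measured compounds named here, the only measured step at this position is the one from compound 1 to compound 2, and that stayed within the scatter. Going by the values given here, no step from isopropyl to cyano has been measured. On that basis a step in this assay of no more than the scatter is expected, in either direction. For compound 4 the expected step is a 1.5-fold higher number from compound 2 to compound 4 (0.18 log units; within the scatter), so compound 4 is estimated at 18000 nM, with a range from 7000 nM to 45000 nM.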

Compound 4, concentration for 50% growth inhibition: 71000 nM
Estimate against measurement, compound 4: 3.9-fold (0.60 log units) below, and the stated range ends below it.
By their numbers in this assay, from the lowest: compounds 2 and 1 (each within the scatter of the next); then compounds 4 and 3 (each within the scatter of the next).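

In this assay this position proves able to shift the number: the step from fluoro to isopropyl had stayed within the scatter, whereas cyano in place of isopropyl gives a 5.9-fold higher number from compound 2 to compound 4 (0.77 log units; beyond the scatter) and so moves clearly beyond it. Cyano in place of fluoro gives a 3.2-fold higher number from compound 1 to compound 4 (0.51 log units; beyond the scatter) and also lies beyond the scatter, so among these three single groups on the aromatic carbon, cyano goes with the weakest inhibition of growth. Nothing given here explains this difference.

As far as these compounds go, whether an amine or a carboxylic acid at this same place would give a number nearer to that of compound 2 or that of compound 4 remains open. So does whether a longer chain in place of isopropyl would lower the number further or leave it within the scatter.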